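Replacing Dimethylamino with Pyrrolidinyl on the Aminopropyl Chain

This account rests on a few compounds, and the source may have more. Where it says the series, first, only, none or still open, it means among the compounds named here.

Measured compounds:
compound 1, `CCCCCCCCCCc1ccc(-c2noc(CCCN(C)C)n2)cc1`, 8%
compound 2, `CCCCCCCCCCc1ccc(-c2noc([C@@H](N)CCCCN)n2)cc1`, 43%
compound 3, `CCCCCCCCCCc1ccc(-c2noc([C@H](CCCCN)NC(C)=O)n2)cc1`, 40%

In an assay on HeLa cells for inhibition of sphingosine-1-phosphate transporter SPNS2 (Mus musculus), read by LC-MS, tested at 2 uM (a higher number here means more inhibition at the concentration tested (going by the name of the read-out), a lower number less inhibition), compound 1 gives 8%, the lowest of the three numbers. Compound 2 sits a number 35 percentage points higher from compound 1 to compound 2 (beyond the scatter), and compound 3 sits a number 32 percentage points higher from compound 1 to compound 3 (beyond the scatter); between compound 2 and compound 3 the change is a number 3 percentage points lower from compound 2 to compound 3 (within the scatter).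

Compound 4, `CCCCCCCCCCc1ccc(-c2noc(CCCN3CCCC3)n2)cc1`, is not yet measured. Relative to compound 1 it carries the following change: pyrrolidin-1-yl in place of dimethylamino on a saturated chain carbon, three bonds along the chain from an aromatic carbon

Neither measured step resembles this one. Both large steps, from compound 1 to compound 2 and from compound 1 to compound 3, replaced the whole 3-(dimethylamino)propyl chain with a 1,5-diaminopentyl or 1-acetamido-5-aminopentyl group; the step from compound 2 to compound 3 touched an amine nitrogen and stayed within the scatter. For compound 4 the chain is kept and only the dimethylamino is exchanged for pyrrolidin-1-yl, so no step beyond the scatter is expected in this assay, in either direction. Compound 4 is estimated at 12%, with a range from 0% to 30%. The expected step is a number 4 percentage points higher from compound 1 to compound 4 (within the scatter).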

Compound 4, a percentage reported as inhibition, at one concentration (the size of the read-out at that concentration, not a potency): 3%
Beside the measured number, compound 4's estimate is 9 percentage points above it; the range from low to high includes it.
By their numbers in this assay, from the lowest: compounds 4 and 1 (each within the scatter of the next); then compounds 3 and 2 (each within the scatter of the next).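

In this assay, exchanging dimethylamino for pyrrolidin-1-yl on a saturated chain carbon, three bonds along the chain from an aromatic carbon, gives a number 5 percentage points lower from compound 1 to compound 4 (within the scatter) and so shows that this read-out does not separate the open dimethylamino group from the five-membered non-aromatic ring at this place. With the 3-(pyrrolidin-1-yl)propyl chain in place, the comparison with the two longer groups gives a number 37 percentage points lower from compound 3 to compound 4 (beyond the scatter) and a number 40 percentage points lower from compound 2 to compound 4 (beyond the scatter), so among these compounds the large gaps go with the exchange of the whole chain and not with this change to the group at its end. The compounds shown offer no measurement that would explain why this exchange stays within the scatter.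

Going by these compounds, it remains open whether a piperidin-1-yl or morpholin-4-yl ring, or a primary amine, on the same propyl chain would leave the number where it is. On these data alone, it also remains open whether a plain 5-aminopentyl chain, without the amine or acetamido group on its first carbon, would match the 1,5-diaminopentyl group of compound 2 or the 1-acetamido-5-aminopentyl group of compound 3.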